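Swapping a chlorophenyl for a dimethoxyphenyl on the chain

The source may hold more compounds than are shown below. What is called first, only, known or untested is meant among the compounds shown, and "the series" means these compounds.

Of the compounds shown here, three built on one shared core have been tested in an ADME assay on HEK293 cells (Homo sapiens) for antiproliferative activity, read by MTT assay, with a stated time of 24 h; on this read-out higher numbers stand for weaker inhibition and lower numbers for stronger inhibition. Compound 1 `COc1cc(-c2cc(C(=O)/C=C/c3ccc(Cl)cc3)nc3cc(-c4ccccc4)nn23)cc(OC)c1OC` gives 53900 nM and holds the highest of the three numbers seen, though every gap to the others lies within the scatter. Compound 2 `COc1ccc(-c2cc(C(=O)/C=C/c3ccc(Cl)cc3)nc3cc(-c4ccccc4)nn23)cc1OC` gives 39100 nM, and compound 3 `COc1cc(-c2cc(/C=C/C(=O)c3ccc(C)cc3)nc3cc(-c4ccccc4)nn23)cc(OC)c1OC` gives 50400 nM.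

Compound 4 `COc1ccc(/C=C/C(=O)c2cc(-c3cc(OC)c(OC)c(OC)c3)n3nc(-c4ccccc4)cc3n2)cc1OC` differs from compound 1 in one place: 3,4-dimethoxyphenyl in place of 4-chlorophenyl on a double-bonded chain carbon bound to a double-bonded chain carbon. For the measured compounds named here, no measured pair shows exactly this exchange. The two steps at hand are only indirect guides. Trimming one methoxy from the aryl group on the core gave a 1.4-fold lower number from compound 1 to compound 2 (0.14 log units; within the scatter), and turning the chain around while exchanging the chloro for a methyl gave a 1.1-fold lower number from compound 1 to compound 3 (0.03 log units; within the scatter). Both changes touch the same region of the molecule as the new exchange, and neither moved the number beyond the scatter.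

The expectation is therefore that the change from compound 1 to compound 4 will also stay within the scatter, with at most a modest shift; the expected step is a 1.1-fold lower number from compound 1 to compound 4 (0.03 log units; within the scatter). Compound 4 is estimated at 50000 nM, with a range from 20000 nM to 130000 nM in this assay.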

Compound 4, half-maximal inhibitory concentration: 41000 nM
Beside the measured number, compound 4's estimate is 1.2-fold (0.09 log units) above it; the range from low to high includes it.
By their numbers in this assay, from the lowest: compounds 2, 4, 3 and 1 (each within the scatter of the next).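

In this assay, exchanging the 4-chlorophenyl for 3,4-dimethoxyphenyl on a double-bonded chain carbon bound to a double-bonded chain carbon gives a 1.3-fold lower number from compound 1 to compound 4 (0.12 log units; within the scatter). This is the first step shown that alters only the aromatic ring at the end of the chain: the earlier steps trimmed a methoxy from the aryl group on the core or turned the chain around, whereas here a chlorine leaves, two methoxy groups enter, and the new group brings hydrogen-bond acceptors that the old one lacks, yet the number stays within the scatter. No measurement of any property of these two groups is available to interpret this result.

On these data alone, both groups compared here are phenyl rings with no net charge, so it remains open whether a ring carrying an amine or a carboxylic acid at this place would also stay within the scatter. As far as these compounds go, it is equally open whether a saturated alkyl chain in place of the ring would move the number, and whether any of these exchanges would give a different picture in another cell line.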